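Acetamido in place of methyl on the aryl amine

The source may hold more compounds than are shown below. What is called first, only, known or untested is meant among the compounds shown, and "the series" means these compounds.

Among the measured compounds shown here, compound 1 `Cc1cccc(N(C)CCCN2CCN(c3ccccc3)CC2)c1` gives 84.8 nM in an assay on HEK293 cells for displacement of a labelled ligand from 5-hydroxytryptamine receptor 7 (Homo sapiens), read by scintillation counting, with a stated time of 30 min (a lower number here means a stronger inhibitor, a higher number a weaker inhibitor), the second highest of the three numbers measured so far. Compound 2 `CN(CCCN1CCN(c2ccccc2)CC1)c1cccc(F)c1` gives 112 nM in this assay, and the step of a 1.3-fold higher number from compound 1 to compound 2 (0.12 log units; within the scatter) lies within the scatter. Compound 3 `Oc1cccc(NCCCN2CCN(c3ccccc3)CC2)c1` differs from compound 1 in two places; in this assay compound 3 gives 10.1 nM, a number lower than that of compound 1 and beyond the scatter. Compound 4 `CC(=O)Nc1cccc(N(C)CCCN2CCN(c3ccccc3)CC2)c1` has not yet been measured. It differs from compound 1 by acetamido in place of methyl on an aromatic carbon. For the measured compounds named here, only one measured step bears directly on an exchange at this aromatic carbon, that from methyl to fluoro, which moved nothing beyond the scatter. Compound 3, which carries hydroxy at this carbon, shows a far lower number, but its second difference leaves unclear how much of that belongs to the ring substituent. Compound 4 is therefore expected to give 50 nM in this assay, within a range from 15 nM to 170 nM. The step of a 1.7-fold lower number from compound 1 to compound 4 (0.23 log units; within the scatter) is expected to be modest, toward a lower number, and may not exceed the scatter.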

Compound 4, inhibition constant: 161 nM
Compound 4: middle estimate off by 3.2-fold (0.51 log units), on the low side; the measured number falls inside the stated range.
By their numbers in this assay, from the lowest: compound 3; then compounds 1, 2 and 4 (each within the scatter of the next).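

In this assay, acetamido on this aromatic carbon, meta to a large group, gives a 1.9-fold higher number from compound 1 to compound 4 (0.28 log units; within the scatter) and a 1.4-fold higher number from compound 2 to compound 4 (0.16 log units; within the scatter). Across compound 1, compound 2 and compound 4, this position therefore takes methyl, fluoro or the larger acetamido, with its hydrogen-bond donor and acceptor, with no difference that the scatter can separate. No measurement shown here gives a cause for this result.

The compounds shown leave open how an amine or a carboxylic acid at this aromatic carbon would read on the core of compound 1. They also leave open whether hydroxy, carried there on that same core, would stand apart from these three groups, which would show how much of the number for compound 3 belongs to the ring substituent.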